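The compounds below may be only part of what the source reports. "The series", "measured", "known", "first", "only" and "open" are said of these compounds alone.

Measured so far:

Compound 1 `O=C(Nc1ccc(Oc2ccnc3[nH]ccc23)c(F)c1)c1nn(-c2ccc(Br)cc2)ccc1=O` – in a functional assay on A549 cells (Homo sapiens) for cytotoxicity, read by MTT assay, with a stated time of 72 h (on this read-out higher numbers stand for weaker inhibition and lower numbers for stronger inhibition), compound 1 gives > 60000 nM, which is a limit of the assay and not a number.
Compound 2 `O=C(Nc1ccc(Oc2ccnc3[nH]ccc23)c(F)c1)c1nn(-c2ccc(Br)cc2F)ccc1=O` – in this assay compound 2 gives 55700 nM.
Compound 3 `Cn1ccc2c(Oc3ccc(NC(=O)c4nn(-c5ccc(Cl)cc5)ccc4=O)cc3)ccnc21` – in this assay compound 3 gives > 60000 nM, again a limit of the assay and not a number.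

Compound 1 and compound 2 share one core and differ in a single place, (fluoro in place of hydrogen on an aromatic carbon). The step that this change made is an at least 1.0-fold lower number from compound 1 to compound 2 (0.03 log units; that floor lies within the scatter). Compound 3 carries a different core; the difference between the two cores is not broken down here.

Compound 4 `Cn1ccc2c(Oc3ccc(NC(=O)c4nn(-c5ccc(Cl)cc5)ccc4=O)cc3F)ccnc21` has not been measured. It differs from compound 3 by fluoro in place of hydrogen on an aromatic carbon. For the measured compounds named here, this is the same kind of change as the one from compound 1 to compound 2, but the surroundings are not identical: in the earlier case the new fluoro sits meta to a bromo group (1 heavy atom), whereas in compound 4 it sits meta to a large group.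

The earlier step rests on a floor set by the limit of > 60000 nM in this assay, at which 2 of the 3 values shown sit, so its true size is not known beyond a lower bound within the scatter. For compound 4 a step of about the same kind is expected, a number no higher from compound 3 to compound 4 (the limit leaves the size open), resting on an at least 1.0-fold lower number from compound 1 to compound 2 (0.03 log units; that floor lies within the scatter) and on (the limit of > 60000 nM in this assay, at which 2 of the 3 values shown sit). Compound 4 is therefore estimated to give 60000 nM in this assay, between 30000 nM and 120000 nM, most likely reported only as a limit.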

Compound 4, half-maximal inhibitory concentration: > 60000 nM
Compound 4 ended at the assay's limit; the forecaster's own chance of this, stated with the estimate: 70%; the middle value lies on the limit itself.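

In this assay compound 4 gives > 60000 nM, which is a limit of the assay and not a number. Compound 3 stands at the same limit, so no step can be read between compound 3 and compound 4: the limit of > 60000 nM in this assay, at which 3 of the 4 values shown sit.

The compounds shown leave open how far compound 3 and compound 4 truly differ, and whether the fluoro changes the number at all.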